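Flipping the linker double bond from E to Z

A few compounds are considered here, and "the series" means these few. Any claim that something is new, unique, unknown or untested is made for them only; others in the source may bear on it.

Two dimer compounds joined through a central linker have been tested. Compound 1 `COc1cc(NC(C)CCCNC(=O)CCC(=O)NCCCC(C)Nc2cc(OC)cc3cccnc23)c2ncccc2c1`, whose linker is a saturated chain, gives 11300 nM in a functional assay on HCT-116 cells (Homo sapiens) for antiproliferative activity, read by MTT assay, with a stated time of 72 h; on this read-out lower numbers stand for stronger inhibition and higher numbers for weaker inhibition. Compound 2 `COc1cc(NC(C)CCCNC(=O)/C=C/C(=O)NCCCC(C)Nc2cc(OC)cc3cccnc23)c2ncccc2c1` carries an E-configured double bond in the same linker. In this assay compound 2 reaches only a limit, >= 100000 nM, which is not a measured number. This marks where compound 2 stands: the limit of >= 100000 nM in this assay, at which 1 of the 2 values shown sits.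

Compound 3 `COc1cc(NC(C)CCCNC(=O)/C=C\C(=O)NCCCC(C)Nc2cc(OC)cc3cccnc23)c2ncccc2c1` is the geometric partner of compound 2: the two compounds have the same atoms and bonds; at least one stereo element is drawn with a configuration in one of them and without one in the other: 1 of 3 stereo elements differ; a double bond is drawn E in compound 2 and Z in compound 3. Among the compounds with values here, no measured pair shows what such a flip does, so the expectation rests on the two values above alone. Compound 3 is expected to return a number rather than a limit, a step of an at least 2.8-fold lower number from compound 2 to compound 3 (0.45 log units; beyond the scatter) toward stronger inhibition, with wide uncertainty. The estimate for compound 3 is 35000 nM, within 8000 nM to 100000 nM.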

Compound 3, half-maximal inhibitory concentration: 9190 nM
Compound 3: middle estimate off by 3.8-fold (0.58 log units), on the high side; the measured number falls inside the stated range.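

In this assay the geometry of the linker double bond matters on its own: the flip from E to Z gives an at least 10-fold lower number from compound 2 to compound 3 (1.03 log units; beyond the scatter) with the atoms and bonds unchanged. That step is only a lower bound, because the value of compound 2 is a limit and not a number: the limit of >= 100000 nM in this assay, at which 1 of the 3 values shown sits. Compound 3 at 9190 nM and compound 1 at 11300 nM lie within the usual scatter of each other, so the Z double bond and the saturated chain cannot be told apart here, and only the E double bond stands apart.

As far as these compounds go, the true number for compound 2, and with it the full size of the step, stays open. Also open, from the compounds shown here alone, is how a longer chain in the linker, or an amine placed within it, would compare with these compounds.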